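Swapping the aryl ether: nitrile out, fluorine in

This account rests on a few compounds, and the source may have more. Where it says the series, first, only, none or still open, it means among the compounds named here.

Measured so far in an assay for inhibition of prostacyclin synthase (Homo sapiens), using microsomes; on this read-out higher numbers stand for weaker inhibition and lower numbers for stronger inhibition:
compound 1, `N#Cc1ccc(C2OCC(C/C=C\CCC(=O)O)C(c3cccnc3)O2)cc1`: > 100000 nM
compound 2, `O=C(O)CC/C=C\CC1COC(c2ccc(Cl)cc2Cl)OC1c1cccnc1`: 2500 nM
compound 3, `Cc1ccc(C#N)c(OC(C)(C)C2OCC(C/C=C\CCC(=O)O)C(c3cccnc3)O2)c1`: > 100000 nM

Compound 3 sits at the limit of > 100000 nM in this assay, at which 2 of the 3 values shown sit; its value is a limit of the assay, not a number. Compound 4, `CC(C)(Oc1ccccc1F)C1OCC(C/C=C\CCC(=O)O)C(c2cccnc2)O1`, differs from it by 2-fluorophenyl in place of 2-cyano-5-methylphenyl on an oxygen on a saturated carbon. Among the measured compounds shown here, the only measured step, an at least 40-fold lower number from compound 1 to compound 2 (1.60 log units; beyond the scatter), likewise replaced a nitrile-bearing phenyl with a halogen-bearing one, though at another place in the shared core. The change to compound 4 again removes the nitrile and brings in a halogen, so a lower number is expected, while its size cannot be fixed from a limit. Compound 4 is therefore estimated at 30000 nM (range 3000 nM to 200000 nM), an expected step of an at least 3.3-fold lower number from compound 3 to compound 4 (0.52 log units; beyond the scatter).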

Compound 4, half-maximal inhibitory concentration: < 1000 nM
Compound 4 gave a limit, no number (the forecaster's own chance of this, stated with the estimate: 45%); middle value at least 30-fold (1.47 log units) away from the limit.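

In this assay, replacing 2-cyano-5-methylphenyl with 2-fluorophenyl on an oxygen on a saturated carbon gives an at least 100-fold lower number from compound 3 to compound 4 (2.00 log units; beyond the scatter). The aryl group at this position therefore moves the read-out strongly, which the earlier step had shown only for a different place on the shared core. The result for compound 4 is a limit, not a number: the limit of < 1000 nM in this assay, at which 1 of the 4 values shown sits.

The compounds shown leave open whether losing the nitrile, losing the methyl or adding the fluorine matters most. They also leave open how a plain phenyl or a 2-chlorophenyl would read at this position.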